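Dropping a Methyl Group: What Cytotoxicity to Expect

This account rests on a few compounds, and the source may have more. Where it says the series, first, only, none or still open, it means among the compounds named here.

Compound 1 `COc1ccc(Cn2c(C(=O)NCc3ccccc3)cc3sccc32)cc1` and compound 2 `COc1ccc(Cn2c(C(=O)NC(C)c3ccccc3)cc3sccc32)cc1` share one core, while compound 3 `CCCNC(=O)C1CCN(C(=O)c2c(CNC(C)c3ccccc3)c3sccc3n2Cc2ccc(OC)cc2)CC1` is built on a different and larger core. In an ADME assay on HEK-293T cells (Homo sapiens) for cytotoxicity, read by luminescence, with a stated time of 24 h (on this read-out higher numbers stand for lower toxicity in this test and lower numbers for higher toxicity in this test), compound 1 gives > 100000 nM, which is a limit of the assay rather than a number. Compound 2 likewise gives > 100000 nM, again a limit. Going by the values given here, compound 3 gives 57500 nM, the only number among the three. The difference between the cores of compound 2 and compound 3 is not broken down here.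

Compound 2 and compound 1 differ in one place only: hydrogen in place of methyl on a saturated chain carbon bound to an amide-type nitrogen and an aromatic carbon. The size of that step, a step that the two limits leave unreadable from compound 2 to compound 1, cannot be read because both values sit at the limit of > 100000 nM in this assay, at which 2 of the 3 values shown sit.

Compound 4 `CCCNC(=O)C1CCN(C(=O)c2c(CNCc3ccccc3)c3sccc3n2Cc2ccc(OC)cc2)CC1` has not yet been measured. It is related to compound 3 by the same kind of change: hydrogen in place of methyl on a saturated chain carbon bound to an amine nitrogen and an aromatic carbon. The surroundings of the place are not identical, though: in compound 2 the saturated chain carbon is bound to an amide-type nitrogen, whereas in compound 3 it is bound to an amine nitrogen. Since the measured instance of this change left no readable size, the expectation for compound 4 rests on compound 3, whose value 57500 nM serves as the anchor, and on the small scale of the change, a single methyl replaced by hydrogen. The step from compound 3 to compound 4 is therefore expected to be a 1.1-fold higher number from compound 3 to compound 4 (0.05 log units; within the scatter), within the usual scatter. Compound 4 is accordingly estimated to give about 65000 nM in this assay.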

Compound 4, half-maximal cytotoxic concentration: 77600 nM
The estimate for compound 4 lay 1.2-fold (0.08 log units) below the measured number, within the range that was stated.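

In this assay, replacing methyl with hydrogen on a saturated chain carbon bound to an amine nitrogen and an aromatic carbon, which turns (1-phenylethyl)amino into benzylamino, gives a 1.3-fold higher number from compound 3 to compound 4 (0.13 log units; within the scatter), so on this larger core the two values cannot be told apart from ordinary repeat-to-repeat variation. Going by these compounds alone, the same kind of change on the other core, where the carbon is bound to an amide-type nitrogen, cannot be read, because compound 2 and compound 1 both stand at a limit of the assay and not at a number: the limit of > 100000 nM in this assay, at which 2 of the 4 values shown sit. The result therefore shows that the methyl made no readable difference in one pair on one core, but it does not show that the change behaves alike on the two cores, as only a single readable step exists and there is no second one to compare it with.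

The compounds shown leave open what happens when the same carbon carries something other than hydrogen or methyl, such as an ethyl group, a hydroxymethyl group or a longer chain. They also leave open whether an amine or a carboxylic acid on the benzyl ring would shift the read-out on either core beyond the usual scatter.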